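The compounds below may be only part of what the source reports. "The series", "measured", "known", "first", "only" and "open" are said of these compounds alone.

Measured in an ADME assay on MCF7-DOX cells (Homo sapiens) for cytotoxicity, read by MTT assay, with a stated time of 48 h; on this read-out lower numbers stand for stronger inhibition and higher numbers for weaker inhibition:
Compound 1 `COc1cccc(/C=C/C(=O)c2c(OC)cc(OC)c(CC=C(C)C)c2O)c1` gives 49200 nM
Compound 2 `COc1cc(OC)c(C(=O)/C=C/c2cccc([N+](=O)[O-])c2)c(O)c1CC=C(C)C` gives 57000 nM

Among the compounds with values here, compound 2 at 57000 nM sits within the scatter of compound 1, the only other compound measured. Compound 3 `COc1cc(OC)c(C(=O)/C=C/c2ccc(Cl)cc2)c(O)c1CC=C(C)C` has not yet been measured. Its difference from compound 2 is 4-chlorophenyl in place of 3-nitrophenyl on a double-bonded chain carbon bound to a double-bonded chain carbon. Within the data shown here, one measured step bears on this change, the nitro in place of methoxy on an aromatic carbon that leads to compound 2, and it shows a 1.2-fold higher number from compound 1 to compound 2 (0.06 log units; within the scatter). Among the measured compounds shown here, no measured compound carries chlorine, so this evidence is thin. The expected step is a 1.3-fold lower number from compound 2 to compound 3 (0.10 log units; within the scatter), with no shift beyond the scatter expected in this assay. For compound 3 the estimated value is 45000 nM, with an expected range from 20000 nM to 95000 nM.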

Compound 3, half-maximal inhibitory concentration: 43400 nM
Compound 3: the middle estimate sits 1.0-fold (0.02 log units) above what was measured; the measured number falls inside the stated range.
By their numbers in this assay, from the lowest: compounds 3, 1 and 2 (each within the scatter of the next).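

In this assay, 4-chlorophenyl in place of 3-nitrophenyl on a double-bonded chain carbon bound to a double-bonded chain carbon gives a 1.3-fold lower number from compound 2 to compound 3 (0.12 log units; within the scatter), and 4-chlorophenyl in place of 3-methoxyphenyl at the same place gives a 1.1-fold lower number from compound 1 to compound 3 (0.05 log units; within the scatter). This position has now carried three different substituted phenyl groups, one of them bearing chlorine, and neither new step goes beyond the scatter, so this read-out does not separate these groups. Nothing available explains this result.

The compounds shown leave open whether any group at this place can move the number beyond the scatter in this assay, for instance a phenyl ring bearing an amine or a carboxylic acid. They also leave open how changes elsewhere on the shared core would behave, since the rest of it is the same in all three compounds.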